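Fluoro in Place of Methyl: Expected Effect on Cell Growth

The compounds below may be only part of what the source reports. "The series", "measured", "known", "first", "only" and "open" are said of these compounds alone.

compound 1 `Cc1ccc2nc(C(=O)Nc3c(F)cc(-c4cccc(F)c4)cc3F)c(C)c(O)c2c1` — 1.06%
compound 2 `Cc1c(C(=O)Nc2c(F)cc(-c3cccc(F)c3)cc2F)nc2ccc(F)cc2c1O` — 0%
compound 3 `Cc1ccc2nc(C(=O)Nc3c(F)cc(-c4cccc(F)c4)cc3F)c(C)c(C(=O)O)c2c1` — 0.98%

In a functional assay on A-375 cells (Homo sapiens) for antiproliferative activity, read by MTT assay, with a stated time of 24 h, tested at 0.14 ug/mL (on this read-out lower numbers stand for a weaker effect and higher numbers for a stronger effect at the one concentration tested), all three measured compounds sit within the scatter of one another. Compound 3 stands with compound 1 nearest to it and compound 2 furthest, none of the gaps reaching beyond the scatter. Compound 4 `Cc1c(C(=O)Nc2c(F)cc(-c3cccc(F)c3)cc2F)nc2ccc(F)cc2c1C(=O)O` differs from compound 3 by fluoro in place of methyl on an aromatic carbon. The same change has already been tried once on this core, from compound 1 to compound 2, where it gave a number 1.1 percentage points lower from compound 1 to compound 2 (within the scatter). That step bears directly on the present one. Because the step of a number 1.1 percentage points lower from compound 1 to compound 2 (within the scatter) stayed within the scatter, compound 4 is expected to show a number 0.5 percentage points lower from compound 3 to compound 4 (within the scatter), nothing beyond the scatter. Compound 4 is therefore estimated at 0.5%, with a range from 0% to 8%.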

Compound 4, a percentage reported as inhibition, at one concentration (the size of the read-out at that concentration, not a potency): 1.05%
Compound 4: the middle estimate sits 0.6 percentage points below what was measured, within the range that was stated.
By their numbers in this assay, from the lowest: compounds 2, 3, 4 and 1 (each within the scatter of the next).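

In this assay, fluoro in place of methyl on an aromatic carbon gives a number 0.1 percentage points higher from compound 3 to compound 4 (within the scatter), and this change has now been read with both hydroxy and carboxy present, with two results that agree within the scatter: the same change on two cores in this assay, a number 1.1 percentage points lower (within the scatter) from compound 1 to compound 2 and a number 0.1 percentage points higher (within the scatter) from compound 3 to compound 4, 1.1 percentage points apart, within the scatter of two such steps. Carboxy in place of hydroxy on an aromatic carbon, now read with fluoro present, gives a number 1.1 percentage points higher from compound 2 to compound 4 (within the scatter), and the two readings of this change also agree: the same change on two cores in this assay, a number 0.1 percentage points lower (within the scatter) from compound 1 to compound 3 and a number 1.1 percentage points higher (within the scatter) from compound 2 to compound 4, 1.1 percentage points apart, within the scatter of two such steps. Neither change separates any of the compounds at this one concentration. From the compounds shown here alone, whether an amine or a longer chain on this aromatic carbon would give a step beyond the scatter remains open. So does whether these compounds would separate at another concentration.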